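Benzothiazolyl amide in place of fluoroanilide

The compounds below may be only part of what the source reports. "The series", "measured", "known", "first", "only" and "open" are said of these compounds alone.

Compound 3 `O=C(COc1ccc2cc(/C=C3/SC(=O)NC3=O)ccc2c1)Nc1ccc(F)cc1` gives 1600 nM in an assay on isolated protein for inhibition of histone deacetylase 4 (Homo sapiens), with a stated time of 1 h; a higher number here means a weaker inhibitor, a lower number a stronger inhibitor. Compound 1 `Cc1ccc(NC(=O)COc2ccc3cc(/C=C4/SC(=O)NC4=O)ccc3c2)cc1` gives 1700 nM in this assay, and compound 2 `O=C(COc1ccc2cc(/C=C3/SC(=O)NC3=O)ccc2c1)Nc1ccccc1` gives 2100 nM; the three numbers sit within the scatter of one another, so compound 3 cannot be set apart from the other two. The steps among them, a 1.2-fold higher number from compound 1 to compound 2 (0.09 log units; within the scatter), a 1.1-fold lower number from compound 1 to compound 3 (0.03 log units; within the scatter) and a 1.3-fold lower number from compound 2 to compound 3 (0.12 log units; within the scatter), all concern a single substituent on the aromatic ring of the amide and none leaves the scatter.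

Compound 4 `Cc1cccc2sc(NC(=O)COc3ccc4cc(/C=C5/SC(=O)NC5=O)ccc4c3)nc12` differs from compound 3 by 4-methyl-1,3-benzothiazol-2-yl in place of 4-fluorophenyl on an amide-type nitrogen. Within the data shown here, no measured step covers an exchange of the whole aryl group on the amide nitrogen; the three known steps only show that small changes on that ring leave the number unmoved. The expectation for compound 4 is therefore a step of a 1.1-fold lower number from compound 3 to compound 4 (0.03 log units; within the scatter), with no direction that the data can support and a wide range. The estimate for compound 4 in this assay is 1500 nM, between 500 nM and 4500 nM.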

Compound 4, half-maximal inhibitory concentration: 1200 nM
Compound 4: middle estimate off by 1.3-fold (0.10 log units), on the high side; low and high end bracket the measured number.
By their numbers in this assay, from the lowest: compounds 4, 3, 1 and 2 (each within the scatter of the next).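

Working notes on the amide-type nitrogen: in this assay this position tolerates exchange of the whole aryl group, not only of a small substituent on it. The steps are a 1.3-fold lower number from compound 3 to compound 4 (0.12 log units; within the scatter) and a 1.8-fold lower number from compound 2 to compound 4 (0.24 log units; within the scatter) and also a 1.4-fold lower number from compound 1 to compound 4 (0.15 log units; within the scatter) and so the fused 4-methyl-1,3-benzothiazol-2-yl, with its hydrogen-bond acceptors, cannot be set apart from the three simple aryl groups. Nothing available bears on why the number stays within the scatter.

Still open is whether the methyl of the benzothiazole contributes anything, since the unsubstituted 1,3-benzothiazol-2-yl is not among the compounds shown. Also open, on these data alone, is whether any group on this nitrogen can move the number beyond the scatter, for instance a phenyl carrying a carboxylic acid or a dimethylamino group, or a saturated cyclohexyl ring.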